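The source may hold more compounds than are shown below. What is called first, only, known or untested is meant among the compounds shown, and "the series" means these compounds.

Measured so far:
compound 1, `CCC(C)(C)Cc1c[nH]c(CCc2ccc(-n3ccnn3)cc2)n1`: 641 nM
compound 2, `CCC(C)(C)Cc1c[nH]c(CCc2ccc(-c3cccnc3)cc2)n1`: 131 nM

Among the two compounds measured in a functional assay on HEK293 cells for agonist activity at Bombesin receptor subtype-3 (Homo sapiens), read by luminescence and calcium flux, with a stated time of 10 min (on this read-out higher numbers stand for an effect only at larger amounts of compound and lower numbers for an effect already at smaller amounts), compound 2 has the lowest number. Among the measured compounds shown here, its only neighbour is compound 1, and the single measured step, a 4.9-fold lower number from compound 1 to compound 2 (0.69 log units; beyond the scatter), is a swap of one ring for another on the same aromatic carbon of the shared core.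

Compound 3, `CCC(C)(C)Cc1c[nH]c(CCc2ccc(N3CCCCC3)cc2)n1`, differs from compound 2 in one place: piperidin-1-yl in place of pyridin-3-yl on an aromatic carbon. For the measured compounds named here, the one measured step bears on it only loosely. It shows that exchanging the ring at this position can shift the number well beyond the scatter, but it compared two aromatic rings, whereas here an aromatic ring gives way to a saturated one attached through its nitrogen. Going by the values given here, no measured pair covers that kind of change, so the direction rests on a cautious reading: a modest move toward higher numbers is expected, and the expected step is a 2.3-fold higher number from compound 2 to compound 3 (0.36 log units; beyond the scatter). Compound 3 is therefore estimated at 300 nM, within a range from 80 nM to 1200 nM.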

Compound 3, half-maximal effective concentration: 171 nM
Estimate against measurement, compound 3: 1.8-fold (0.24 log units) above, within the range that was stated.
By their numbers in this assay, from the lowest: compounds 2 and 3 (each within the scatter of the next); then compound 1.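

In this assay, the move from an aromatic to a saturated ring at this place, on a six-membered aromatic ring of carbon only, stays within the scatter (a 1.3-fold higher number from compound 2 to compound 3 (0.12 log units; within the scatter)), so among these compounds an aromatic ring is not needed for the lower numbers seen with compound 2. Compound 3 also keeps the gap from the triazole compound beyond the scatter (a 3.7-fold lower number from compound 1 to compound 3 (0.57 log units; beyond the scatter)), which means that compound 1 stands apart from two six-membered rings that differ in aromatic character, and the earlier pair of aromatic rings could not show this. Nothing measured here explains why piperidin-1-yl and pyridin-3-yl give readings that cannot be told apart.

From the compounds shown here alone, how a phenyl or cyclohexyl ring, with only carbon atoms in the ring, would compare remains open, so the part played by the ring nitrogen cannot be judged from these compounds. Also open, going by these compounds, is whether a ring is needed here at all, a question that an open-chain group such as diethylamino at the same place would address.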